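Thiazole Acetic Acid Series: Amino-methylpyridine in Place of Sulfonamide

A few compounds are considered here, and "the series" means these few. Any claim that something is new, unique, unknown or untested is made for them only; others in the source may bear on it.

Three compounds of the series have numbers in an in vitro functional assay on HEK285-7 cells for antagonist activity at prostaglandin D2 receptor 2 (Homo sapiens), read by BRET and beta-arrestin recruitment; on this read-out lower numbers stand for stronger inhibition and higher numbers for weaker inhibition. Compound 1 `Cc1nc(-c2ccc(Cl)cc2)c(CC(=O)O)s1` gives 41000 nM in this assay. Compound 2 `O=C(O)Cc1sc(C2COc3ccccc3O2)nc1-c1ccc(Cl)cc1` gives 2000 nM in this assay. Compound 3 `CS(=O)(=O)Nc1cccc(-c2nc(C(c3ccc(F)cc3)c3ccc(F)cc3)sc2CC(=O)O)c1` gives 370 nM in this assay, the lowest of the three numbers; the nearest is compound 2 with a number that lies beyond the scatter above it, and compound 1 lies further still. None of these pairs differ in a single place, so the numbers stand side by side without a computed step.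

Compound 4 `Cc1cc(-c2nc(C(c3ccc(F)cc3)c3ccc(F)cc3)sc2CC(=O)O)cnc1N` has not yet been measured in this assay. It is made from compound 3 by one change: 6-amino-5-methylpyridin-3-yl in place of 3-(methanesulfonamido)phenyl on an aromatic carbon. The group that leaves and the group that enters carry the same count of hydrogen-bond donors and acceptors, and the rest of the molecule is unchanged. With no measured step of this kind in the series, the expected step from compound 3 to compound 4 in this assay is a 1.1-fold lower number from compound 3 to compound 4 (0.02 log units; within the scatter), that is, no change beyond the scatter, with a wide range either way. Compound 4 is therefore expected to give about 350 nM in this assay, within a range from 90 nM to 1400 nM.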

Compound 4, half-maximal inhibitory concentration: > 100000 nM
Compound 4: a limit, no number (the forecaster's own chance of this, stated with the estimate: 3%); middle value at least 280-fold (2.45 log units) from the limit.
By their numbers in this assay, from the lowest: compound 3; then compound 2; then compound 1. At a limit, above all of these: compound 4.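

In this assay, for the compounds shown here, the first single-place step, on the aromatic carbon next to the ring nitrogen, is 6-amino-5-methylpyridin-3-yl in place of 3-(methanesulfonamido)phenyl: it gives an at least 270-fold higher number from compound 3 to compound 4 (2.43 log units; beyond the scatter). Compound 4 stands at a limit of the assay and not at a number: the limit of > 100000 nM in this assay, at which 1 of the 4 values shown sits. The leaving and entering groups carry the same hydrogen-bond donor and acceptor counts, so matching counts at this position did not go with matching numbers.

Going by these compounds alone, the single step does not separate the contributions of the ring nitrogen, the amino group, the methyl group and the methanesulfonamido group. A phenyl ring carrying an amine, or a pyridine ring carrying the methanesulfonamido group, at this position would tell these parts apart.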